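This account rests on a few compounds, and the source may have more. Where it says the series, first, only, none or still open, it means among the compounds named here.

- Compound 1 `CCOC(=O)c1c(-c2cccc(OCC)c2)[nH]c2cc(OC)ccc2c1=O`: > 21500 nM, a limit
- Compound 2 `CCOC(=O)c1c(-c2cccc(NC(C)=O)c2)[nH]c2cc(OC)ccc2c1=O`: > 21500 nM, a limit

Both results come from an ADME assay on HepG2 cells (Homo sapiens) for cytotoxicity, read by luminescence, with a stated time of 72 h; on this read-out higher numbers stand for an effect only at larger amounts of compound and lower numbers for an effect already at smaller amounts. Compound 2 gives > 21500 nM, which is a limit of the assay and not a number. Compound 3 `CCOC(=O)c1c(-c2cccc(CO)c2)[nH]c2cc(OC)ccc2c1=O` carries hydroxymethyl in place of acetamido on an aromatic carbon, meta to a large group: hydroxymethyl in place of acetamido on an aromatic carbon. Going by the values given here, only one measured step bears on this change, a step that the two limits leave unreadable from compound 1 to compound 2, so it offers no size to carry over. The measured compounds share one result: the limit of > 21500 nM in this assay, at which 2 of the 2 values shown sit. On that basis, no step beyond the scatter is expected in this assay, and no direction can be given. The expected step is a step that the limit leaves unreadable from compound 2 to compound 3. Compound 3 is expected near 25000 nM, with an estimated range from 12000 nM to 50000 nM, and the assay may well report only a limit again.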

Compound 3, half-maximal effective concentration: > 21500 nM
Compound 3: a limit, no number (the forecaster's own chance of this, stated with the estimate: 85%); the middle value does not contradict the limit.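

No new step can be read among compound 1, compound 2 and compound 3, since each result in this assay is a limit of the assay and not a number: the limit of > 21500 nM in this assay, at which 3 of the 3 values shown sit.

The compounds shown leave open what amount of each would produce an effect, and whether ethoxy, acetamido and hydroxymethyl differ at all.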